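The source may hold more compounds than are shown below. What is called first, only, known or untested is meant among the compounds shown, and "the series" means these compounds.

Measured compounds in a functional assay on cells (T-cell, Homo sapiens) for inhibition; a higher number here means a weaker inhibitor, a lower number a stronger inhibitor:
- compound 2 `COc1ccc(-c2cnc3nc(N)nc(N4CCN(C(=O)c5ccccc5)CC4)c3n2)cc1OC`: 400 nM
- compound 3 `CCOc1nc(N)nc2ncc(-c3cccc(OC)c3)nc12`: 8300 nM
- compound 1 `CC(C)Oc1nc(N)nc2ncc(-c3ccc(C#N)cc3)nc12`: > 10000 nM, a limit of the assay, not a number

Among the two numbers shown in this assay, compound 2 gives the lowest; the nearest value, that of compound 3, is higher, beyond the scatter of repeated measurements. Compound 1 sits at the limit of this assay, (the limit of > 10000 nM in this assay, at which 1 of the 3 values shown sits), and so yields no number. Compound 4 `COc1ccc(-c2cnc3nc(N)nc(N4CCN(Cc5ccc(C(C)(C)C)cc5)CC4)c3n2)cc1OC` has not yet been measured. It differs from compound 2 in one place: 4-(tert-butyl)benzyl in place of benzoyl on an amine nitrogen in a ring. Within the data shown here, no pair of measured compounds differs in exactly this way, so nothing measured here tells how large a step this change should bring. The step from compound 2 to compound 4 in this assay is therefore expected to be small, a 1.3-fold lower number from compound 2 to compound 4 (0.12 log units; within the scatter), with no clear direction beyond the scatter. On that basis compound 4 is estimated at 300 nM, with a range from 60 nM to 1500 nM.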

Compound 4, half-maximal inhibitory concentration: 4300 nM
Compound 4: middle estimate off by 14-fold (1.16 log units), on the low side, and the stated range ends below it.
By their numbers in this assay, from the lowest: compound 2; then compounds 4 and 3 (each within the scatter of the next). At a limit, above all of these: compound 1.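

In this assay, among these compounds, 4-(tert-butyl)benzyl in place of benzoyl on an amine nitrogen in a ring gives an 11-fold higher number from compound 2 to compound 4 (1.03 log units; beyond the scatter), so what this ring nitrogen carries clearly matters in this assay, which the earlier compounds could not show. The change takes away the carbonyl, with the hydrogen-bond acceptor counted in benzoyl, and also brings in the tert-butyl group, so this single step does not separate the two. Nothing measured here accounts for the size of the step.

The compounds shown leave open whether the carbonyl or the tert-butyl group carries the step, which plain benzyl and 4-(tert-butyl)benzoyl at this nitrogen would tell apart. They also leave open how an amine or a carboxylic acid on that aromatic ring would read.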